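The source may report more compounds than this note shows. Statements on the series, on what has been measured and on what is new or still open speak of the compounds shown alone.

Compound 1 `Cc1oc(-c2ccc(F)cc2)nc1CN1CCC(C(=O)NCCCN2C[C@H](C)C[C@H](C)C2)CC1` carries a 4-fluorophenyl group on its five-membered aromatic ring, a six-membered ring bearing an amide, and a chain ending in a dimethyl-substituted amine. In a physicochemical assay for permeability, using PAMPA (on this read-out higher numbers stand for higher permeability and lower numbers for lower permeability), the entry for compound 1 reads "not determined" (no result reported), so no number places it on the scale. Compound 2 `Cc1ccccc1-c1nc(CN2CCC(C(=O)NCCCCN3C[C@H](C)C[C@H](C)C3)CC2)c(C)o1` is a close relative with a longer chain; in this assay compound 2 gives 288 10^-6 cm/s. Compound 3 `Cc1cccc(Cl)c1-c1nc(CN2CCC(C(=O)NCCCN3CCC(C)(C)CC3)CC2)c(C)o1` is another relative, and in this assay the entry for compound 3 also reads "not determined" (no result reported). The step from compound 1 to compound 4 `COc1cccc(Br)c1-c1nc(CN2CCC(C(=O)NCCCN3C[C@H](C)C[C@H](C)C3)CC2)c(C)o1` changes one group: 2-bromo-6-methoxyphenyl in place of 4-fluorophenyl on an aromatic carbon. Within the data shown here, no measured pair shows what this change does in this assay, so the expected step cannot be read from a comparison, and the only anchor is the single number for compound 2. On that anchor alone, a comparable value is expected for compound 4, estimated at 250 10^-6 cm/s, with a range from 90 10^-6 cm/s to 600 10^-6 cm/s.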

Compound 4, apparent permeability: 245 10^-6 cm/s
Estimate against measurement, compound 4: 1.0-fold (0.01 log units) above; measured number inside the range.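

No new step can be read from compound 4, as compound 2, its only relative here with a number, differs from it in more than one place. On these data alone, what replacing 4-fluorophenyl with 2-bromo-6-methoxyphenyl does in this assay stays open. Nothing shown accounts for the value of compound 4.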